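Shortening the Ethoxy Chain: From Compound 2 to Compound 4

This account rests on a few compounds, and the source may have more. Where it says the series, first, only, none or still open, it means among the compounds named here.

Compound 1 `CCOC(=O)c1ccnc(-c2ccc(OCC)cc2)c1` gives 87% in an assay on COS-7 cells for inhibition of patatin-like phospholipase domain-containing protein 2 (Mus musculus), tested at 200 uM; on this read-out higher numbers stand for more inhibition at the one concentration tested (going by the name of the read-out) and lower numbers for less inhibition.
Compound 2 `CCOC(=O)c1cccc(-c2ccc(OCC)cc2)c1` gives 87% in this assay.
Compound 3 `CCOC(=O)c1ccc(-c2ccc(OCC)cc2)o1` gives 93% in this assay.

The three measured compounds share an ethyl ester and an ethoxy-bearing aryl group on differing cores, and all three show high inhibition at the single concentration tested. Compound 2 stands level with compound 1 at the digits shown, and together the two are the lowest of the three numbers. Compound 3 lies higher, but that gap falls within the usual scatter of repeated measurements, so no order among the three can be claimed.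

Compound 4 `CCOC(=O)c1cccc(-c2ccc(OC)cc2)c1` has not yet been measured. It differs from compound 2 in one place: hydrogen in place of methyl on a saturated chain carbon bound to an oxygen on an aromatic ring. Going by the values given here, no pair of measured compounds shows this kind of change, so its effect has to be guessed from the general picture. The step of a number 5 percentage points lower from compound 2 to compound 4 (within the scatter) is expected to stay within the scatter, with no firm direction. This expectation rests on compound 2, which gives 87%, and on the smallness of the change, a single carbon leaving a short chain. Compound 4 is therefore estimated at 82%, with a range from 60% to 95%.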

Compound 4, a percentage reported as inhibition, at one concentration (the size of the read-out at that concentration, not a potency): 77%
Compound 4: the middle estimate sits 5 percentage points above what was measured; low and high end bracket the measured number.
By their numbers in this assay, from the lowest: compounds 4, 1, 2 and 3 (each within the scatter of the next, the first and the last beyond it).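

Ethoxy to methoxy is the first change in the set that can be read in one place, since compounds 1, 2 and 3 differ in their cores and say nothing about this chain. In this assay, replacing methyl with hydrogen on the saturated chain carbon bound to an oxygen on an aromatic ring gives a number 10 percentage points lower from compound 2 to compound 4 (within the scatter), so on the core of compound 2 the chain can be shortened from ethyl to methyl without a change that stands out from repeat-to-repeat variation, although this read-out shows the size of the effect at one concentration and is not a potency. No measurement offered here gives a reason for this step.

The compounds shown carry only ethoxy and methoxy at this place, so it stays open what a longer chain such as propoxy, a hydroxyl or an amine would give there. From the compounds shown here alone, it also stays open whether the same shortening would behave alike on the cores of compound 1 and compound 3, and whether compound 2 and compound 4 would separate at lower concentrations.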